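Trimming the chain end of compound 2

This account rests on a few compounds, and the source may have more. Where it says the series, first, only, none or still open, it means among the compounds named here.

Compound 1 `CCCCCCCNC[C@@H]1OC[C@H](N)[C@H]1O`: > 128000 nM, a limit
Compound 2 `CCCCCCCCCCCNC[C@@H]1OC[C@H](N)[C@H]1O`: 88800 nM

Within the data shown here, in a functional assay on B16-F10 cells (Mus musculus) for antiproliferative activity, read by MTT assay, with a stated time of 72 h (a higher number here means a weaker inhibitor, a lower number a stronger inhibitor), compound 2 gives 88800 nM, the only actual number so far. Compound 1 reports only a limit, > 128000 nM. Compound 3 `CCCCCCCCCCNC[C@@H]1OC[C@H](N)[C@H]1O` differs from compound 2 by hydrogen in place of methyl on a saturated chain carbon, ten or more bonds along the chain from an amine nitrogen. Among the measured compounds shown here, the one measured step that bears on this is an at least 1.4-fold lower number from compound 1 to compound 2 (0.15 log units; that floor lies within the scatter), butyl in place of hydrogen on a saturated chain carbon, so only a slight rise in the number is expected. The estimated step is a 1.2-fold higher number from compound 2 to compound 3 (0.07 log units; within the scatter), which stays within the scatter. Compound 3 is expected at 105000 nM, with an estimated range of 70000 nM to 128000 nM.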

Compound 3, half-maximal inhibitory concentration: > 128000 nM
Compound 3: a limit, no number; the forecaster's own chance of this, stated with the estimate: 30%; middle value at least 1.2-fold (0.08 log units) from the limit.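

In this assay, hydrogen in place of methyl at this position gives an at least 1.4-fold higher number from compound 2 to compound 3 (0.15 log units; that floor lies within the scatter). Compound 3 reports only a limit, so this step has a floor but no full size, and it does not show whether the true gap lies beyond the scatter: the limit of > 128000 nM in this assay, at which 2 of the 3 values shown sit. Among these compounds, the step between the limits of compound 1 and compound 3 cannot be read, which leaves compound 2 as the only compound with a number. The compounds shown leave open whether a longer chain would give a measurable number, and what an amine or a carboxylic acid in place of the methyl would give.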